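The compounds below may be only part of what the source reports. "The series", "measured", "known", "first", "only" and "open" are said of these compounds alone.

Of the compounds shown here, three with a shared core have numbers so far in a functional assay on SK-BR-3 cells (Homo sapiens) for cytotoxicity, read by sulforhodamine B assay, with a stated time of 72 h; on this read-out lower numbers stand for an effect already at smaller amounts and higher numbers for an effect only at larger amounts of compound. Compound 1 `CCOc1cccc(-c2cc3occ(C)c3c(=O)o2)c1` gives 0.67 uM, compound 2 `Cc1coc2cc(-c3cccc(O)c3)oc(=O)c12` gives 1.61 uM, and compound 3 `Cc1coc2cc(-c3ccc(O)c(O)c3)oc(=O)c12` gives 0.47 uM. Compound 2 therefore has the highest number of the three, so it needs the largest amount to reach its effect.

Compound 4 `Cc1coc2cc(-c3cc(O)cc(O)c3)oc(=O)c12` has not yet been measured. It differs from compound 2 in one place: hydroxy in place of hydrogen on an aromatic carbon. The new hydroxy stands on the six-membered aromatic ring, meta to a hydroxy group and meta to a large group.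

The closest guide is the same kind of exchange, hydroxy in place of hydrogen on an aromatic carbon, seen in a 3.4-fold lower number from compound 2 to compound 3 (0.53 log units; beyond the scatter). That step was modest and went towards a lower number. The other measured step, a 2.4-fold higher number from compound 1 to compound 2 (0.38 log units; beyond the scatter), was also modest, but it concerns the ethyl on an oxygen and so bears on this change only loosely. Among the compounds with values here, the hydroxy of compound 4 sits on a different ring carbon from the one in compound 3, and no measurement yet shows how much that matters.

Within the data shown here, a modest drop, somewhat smaller than the one to compound 3, is therefore expected in this assay. The expected change is a 2.1-fold lower number from compound 2 to compound 4 (0.33 log units; beyond the scatter). For compound 4 the estimated value is 0.75 uM, with an expected range from 0.25 uM to 2 uM.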

Compound 4, concentration for half-maximal effect: 38.4 uM
Compound 4: the middle estimate sits 51-fold (1.71 log units) below what was measured; the measured number lies above the stated range.
By their numbers in this assay, from the lowest: compounds 3 and 1 (each within the scatter of the next); then compound 2; then compound 4.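

In this assay the exchange of hydrogen for hydroxy on an aromatic carbon gives a 24-fold higher number from compound 2 to compound 4 (1.38 log units; beyond the scatter) when the new hydroxy stands meta to a hydroxy group and meta to a large group. On a different ring carbon the same exchange gave a 3.4-fold lower number from compound 2 to compound 3 (0.53 log units; beyond the scatter) and so went the opposite way. Across these two compounds, the ring carbon that carries the new hydroxy therefore decides both the direction and the size of the step, and nothing available explains why.

The compounds shown leave open whether this carbon is sensitive to any added group or mainly to hydroxy, as a methoxy group, an amine or a fluorine atom in the same place would show. They also leave open whether the large rise depends on the hydroxy already on the ring, which a compound with only the new hydroxy could test, and whether an ethyl on the oxygen of either hydroxy in compound 4 would bring the number back down.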